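The compounds below may be only part of what the source reports. "The series", "measured", "known", "first", "only" and "open" are said of these compounds alone.

Compound 1 `O=c1oc2ccccc2c(=O)n1-c1ccc(Cl)cc1F` gives 26500 nM in an ADME assay on RAW264.7 cells (Mus musculus) for cytotoxicity, read by MTT assay, with a stated time of 24 h; on this read-out higher numbers stand for lower toxicity in this test and lower numbers for higher toxicity in this test. Compound 2 `COc1ccc(C(=O)Nc2ccc(Cl)cc2F)c(OCc2ccc(F)cc2F)c1` returns only a limit of the assay in this assay, > 40000 nM. Compound 3 `COc1ccc2c(=O)n(-c3ccc(Cl)cc3F)c(=O)oc2c1` likewise stops at a limit in this assay, > 40000 nM. The step of an at least 1.5-fold higher number from compound 1 to compound 3 (0.17 log units; that floor lies within the scatter) is therefore known only as a floor; with the limit of > 40000 nM in this assay, at which 2 of the 3 values shown sit, two of the three values end at that limit, so compound 3 stands at the limit with no number of its own. Compound 4 `COc1ccc2c(=O)n(-c3ccc(F)cc3F)c(=O)oc2c1` carries fluoro in place of chloro on an aromatic carbon. Within the data shown here, no measured step swaps these halogens; the only bearing step is an at least 1.5-fold higher number from compound 1 to compound 3 (0.17 log units; that floor lies within the scatter), which sits elsewhere, so nothing beyond the scatter is expected in this assay. The estimate for compound 4 is 40000 nM, between 20000 nM and 80000 nM, an expected step of a number no higher from compound 3 to compound 4 (the limit leaves the size open).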

Compound 4, half-maximal cytotoxic concentration: > 40000 nM
Compound 4 ended at the assay's limit (the forecaster's own chance of this, stated with the estimate: 65%); the middle value sits exactly at the limit.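

Compound 3 and compound 4 both stop at a limit in this assay, so fluoro in place of chloro gives no readable step: the limit of > 40000 nM in this assay, at which 3 of the 4 values shown sit.

The compounds shown leave open whether this swap shifts the cytotoxicity at all.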